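From cyclohexylamino to diethylamino on a shared core

The source may hold more compounds than are shown below. What is called first, only, known or untested is meant among the compounds shown, and "the series" means these compounds.

In an ADME assay on A549 cells (Homo sapiens) for cytotoxicity, read by resazurin assay, with a stated time of 48 h (a lower number here means that less compound is tolerated, a higher number that more compound is tolerated), compound 1 `CCCNc1ccc(NC(=O)c2cc(Cl)ccc2O)c(Cl)c1` gives 22500 nM, compound 2 `O=C(Nc1ccc(NCC2CCCC2)cc1Cl)c1cc(Cl)ccc1O` gives 21500 nM and compound 3 `O=C(Nc1ccc(NC2CCCCC2)cc1Cl)c1cc(Cl)ccc1O` gives 68300 nM. Compound 3 therefore has the highest number of the three. Compound 4 `CCN(CC)c1ccc(NC(=O)c2cc(Cl)ccc2O)c(Cl)c1` has not been measured yet. It differs from compound 3 as follows: diethylamino in place of cyclohexylamino on an aromatic carbon. In short, diethylamino stands in place of cyclohexylamino on an aromatic carbon.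

For the measured compounds named here, no measured step makes this exact swap, and no measured compound carries diethylamino. The nearest evidence is a 3.0-fold higher number from compound 1 to compound 3 (0.48 log units; beyond the scatter) and a 3.2-fold higher number from compound 2 to compound 3 (0.50 log units; beyond the scatter), both modest steps in which a cyclohexyl group enters. By contrast, a 1.0-fold lower number from compound 1 to compound 2 (0.02 log units; within the scatter) involves no cyclohexyl group. Losing the cyclohexyl group from compound 3 may therefore reverse those steps, so a modest move towards a lower number is expected, though this is uncertain. The expected change is a 2.3-fold lower number from compound 3 to compound 4 (0.36 log units; beyond the scatter). Compound 4 is estimated at 30000 nM, with an expected range from 12000 nM to 70000 nM.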

Compound 4, half-maximal cytotoxic concentration: 55500 nM
Compound 4: the middle estimate sits 1.9-fold (0.27 log units) below what was measured; the measured number falls inside the stated range.
By their numbers in this assay, from the lowest: compounds 2 and 1 (each within the scatter of the next); then compounds 4 and 3 (each within the scatter of the next).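

In this assay, the cyclohexyl ring turns out not to be needed for a high number at this position: the open-chain diethylamino group, with no ring and no hydrogen-bond donor, gives (a 1.2-fold lower number from compound 3 to compound 4 (0.09 log units; within the scatter)). Compound 4 also stands apart from its other open-chain relative, with propylamino replaced by diethylamino (a 2.5-fold higher number from compound 1 to compound 4 (0.39 log units; beyond the scatter)), and from the ring-bearing compound 2 (a 2.6-fold higher number from compound 2 to compound 4 (0.41 log units; beyond the scatter)), so the mere presence of a ring does not sort these compounds. Nothing measured here explains these differences.

On these data alone, it remains open whether a dimethylamino group or a pyrrolidine ring at this position would group with compounds 3 and 4 or with compounds 1 and 2. A morpholine ring there is equally unresolved.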